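From methoxy to tert-butyl: a working estimate

This account rests on a few compounds, and the source may have more. Where it says the series, first, only, none or still open, it means among the compounds named here.

In a functional assay for inhibition, with Homo sapiens as the target (a lower number here means tighter binding, a higher number weaker binding), compound 1 `CC(C)(Oc1ccccc1)C1OCC(C/C=C\CCC(=O)O)C(c2cccnc2)O1` gives 75.9 nM, compound 2 `CSc1ccc(OC(C)(C)C2OCC(C/C=C\CCC(=O)O)C(c3cccnc3)O2)c([N+](=O)[O-])c1` gives 4.47 nM and compound 3 `COc1ccc(OC(C)(C)C2OCC(C/C=C\CCC(=O)O)C(c3cccnc3)O2)cc1` gives 302 nM. Compound 3 therefore has the highest number of the three and the weakest binding.

Compound 4 `CC(C)(C)c1ccc(OC(C)(C)C2OCC(C/C=C\CCC(=O)O)C(c3cccnc3)O2)cc1` has tert-butyl in place of methoxy on an aromatic carbon, para to a large group: tert-butyl in place of methoxy on an aromatic carbon.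

The closest evidence is a 4.0-fold higher number from compound 1 to compound 3 (0.60 log units; beyond the scatter), where methoxy replaces hydrogen on an aromatic carbon. The other two steps, a 17-fold lower number from compound 1 to compound 2 (1.23 log units; beyond the scatter) and a 68-fold higher number from compound 2 to compound 3 (1.83 log units; beyond the scatter), exchange larger groups and bear on this change only loosely. They do show that the number can move widely with the groups on that ring. For the measured compounds named here, no measured compound carries tert-butyl, so the direction remains an expectation. With methoxy gone, a partial return towards the value of compound 1 at 75.9 nM is expected.

The expected change is modest and towards a lower number, estimated as a 3.0-fold lower number from compound 3 to compound 4 (0.48 log units; beyond the scatter).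

The estimated value for compound 4 is 100 nM, with an expected range of 25 nM to 400 nM.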

Compound 4, dissociation constant: 1910 nM
The estimate for compound 4 lay 19-fold (1.28 log units) below the measured number; measured number above the stated range.
By their numbers in this assay, from the lowest: compound 2; then compound 1; then compound 3; then compound 4.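

In this assay, tert-butyl on an aromatic carbon para to a large group moves the number further up, not back towards the hydrogen compound: a 6.3-fold higher number from compound 3 to compound 4 (0.80 log units; beyond the scatter), and overall a 25-fold higher number from compound 1 to compound 4 (1.40 log units; beyond the scatter). Across hydrogen, methoxy and tert-butyl at this place, the number rises with each step in heavy-atom count, a pattern limited to compound 1, compound 3 and compound 4; compound 2 goes against it, carrying the largest group and the lowest number, with a 430-fold higher number from compound 2 to compound 4 (2.63 log units; beyond the scatter). No measurement in hand accounts for this rise.

Still open, on these data alone, is how an amine, a hydroxyl or a fluorine at this place would read against hydrogen and methoxy. As far as these compounds go, it is also open which part of the ring substitution in compound 2 carries its low number.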